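The source may hold more compounds than are shown below. What is called first, only, known or untested is meant among the compounds shown, and "the series" means these compounds.

Compound 1 `O=C(Nc1ccc([N+](=O)[O-])cc1)Nc1cccc(CNc2ncnc3ccccc23)c1` and compound 2 `O=C(Nc1cccc(CNc2ncnc3ccccc23)c1)Nc1cccc(C(F)(F)F)c1` are built on the same core and differ only in the group carried on the urea. In a functional assay on HepG2 cells (Homo sapiens) for antiproliferative activity, read by MTT assay (a lower number here means a stronger inhibitor, a higher number a weaker inhibitor), compound 1 gives 24600 nM, while compound 2 gives 40000 nM. The change between them, (3-(trifluoromethyl)phenyl in place of 4-nitrophenyl on an amide-type nitrogen), produced a 1.6-fold higher number from compound 1 to compound 2 (0.21 log units; within the scatter), so within this pair the two aryl groups cannot be told apart with confidence.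

Compound 3 `COc1cc2ncnc(NCc3cccc(NC(=O)Nc4ccc([N+](=O)[O-])cc4)c3)c2cc1OC` carries the same 4-nitrophenyl urea as compound 1 but on a different core; how the two cores differ is not broken down here. In this assay compound 3 gives 18800 nM, which lies within the scatter of compound 1 and beyond it only against compound 2.

Compound 4 `COc1cc2ncnc(NCc3cccc(NC(=O)Nc4cccc(C(F)(F)F)c4)c3)c2cc1OC` has not yet been measured. It stands to compound 3 as compound 2 stands to compound 1: the change is 3-(trifluoromethyl)phenyl in place of 4-nitrophenyl on an amide-type nitrogen, and since the place of the change reads the same in both pairs, it is the same change made on the other core. Among the measured compounds shown here, the only guide to its effect is the step from compound 1 to compound 2, which was small. On that basis compound 4 is expected to show about a 1.6-fold higher number from compound 3 to compound 4 (0.20 log units; within the scatter) relative to compound 3, the expectation resting on a 1.6-fold higher number from compound 1 to compound 2 (0.21 log units; within the scatter). The estimate for compound 4 in this assay is therefore 30000 nM, with a plausible range from 12000 nM to 75000 nM.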

Compound 4, half-maximal inhibitory concentration: 34200 nM
Estimate against measurement, compound 4: 1.1-fold (0.06 log units) below; the range from low to high includes it.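

In this assay, putting 3-(trifluoromethyl)phenyl in place of 4-nitrophenyl on the amide-type nitrogen gave a 1.8-fold higher number from compound 3 to compound 4 (0.26 log units; within the scatter), so on this core too the two aryl groups cannot be told apart with confidence. Set beside the earlier step, the change reads the same on the core of compound 1 and on the core of compound 3, and in this series it carried from one core to the other without a visible difference: the same change on two cores in this assay, a 1.6-fold higher number (0.21 log units; within the scatter) from compound 1 to compound 2 and a 1.8-fold higher number (0.26 log units; within the scatter) from compound 3 to compound 4, 1.1-fold (0.05 log units) apart, within the scatter of two such steps This does not show that the change has a real effect that travels between cores, since each step is itself within the scatter and the agreement is only between two small steps, on two cores, in a single assay.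

The compounds shown leave open whether any group on the urea would move the number beyond the scatter, and whether such a step would carry across the two cores as this one did. An aryl ring bearing an amine or a carboxylic acid in place of the nitro or trifluoromethyl group, or a plain alkyl chain in place of the aryl ring, would speak to this, and the present pairs say nothing about them.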